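A few compounds are considered here, and "the series" means these few. Any claim that something is new, unique, unknown or untested is made for them only; others in the source may bear on it.

Measured compounds in a functional assay on ACHN cells (Homo sapiens) for inhibition, read by sulforhodamine B assay; on this read-out higher numbers stand for weaker inhibition of growth and lower numbers for stronger inhibition of growth:
compound 1 `O=C(CCC1=CCN(CCCc2ccc(Br)cc2)C1=O)NO`, 3330 nM
compound 2 `O=C(CCC1=CCN(CCCc2ccc(Cl)cc2)C1=O)NO`, 3330 nM
compound 3 `Cc1ccc(CN2CC=C(CCC(=O)NO)C2=O)cc1`, 3330 nM

Compound 3 stands level with compounds 1 and 2 on the numbers shown; its value is within the scatter of both. Among the compounds with values here, the only step measured between compounds that differ in one place is the one from compound 1 to compound 2, no change at the digits printed from compound 1 to compound 2 (within the scatter), a halogen exchange on the aromatic ring that left this assay unchanged.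

Compound 4 `CC(C)(C)c1ccc(CN2CC=C(CCC(=O)NO)C2=O)cc1` differs from compound 3 by tert-butyl in place of methyl on an aromatic carbon. Within the data shown here, no measured step concerns a change of this kind; the exchange from compound 1 to compound 2 shows only that one substituent swap on the aromatic ring made no difference. Among the measured compounds shown here, with all three measured compounds level and no informative precedent, no step beyond the scatter is expected from compound 3 to compound 4, and the estimated step is a 1.0-fold lower number from compound 3 to compound 4 (0.00 log units; within the scatter). Compound 4 is therefore expected to give about 3300 nM, with a range from 1400 nM to 8000 nM.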

Compound 4, concentration for 50% growth inhibition: 860 nM
For compound 4 the middle estimate is 3.8-fold (0.58 log units) above the measured one; the measured number lies below the stated range.
By their numbers in this assay, from the lowest: compound 4; then compounds 1, 2 and 3 (each within the scatter of the next).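

In this assay, within the data shown here, the exchange of methyl for tert-butyl on an aromatic carbon, para to a large group, gives a 3.9-fold lower number from compound 3 to compound 4 (0.59 log units; beyond the scatter) and is the first step beyond the scatter. This position therefore responds to the group it carries, whereas the halogen exchange, with no change at the digits printed from compound 1 to compound 2 (within the scatter) on the other chain, gave no separation. No measurement at hand accounts for the step.

Open, from the compounds shown here alone, is how the read-out changes across this position with intermediate or different groups, such as ethyl, isopropyl, an amine or a carboxylic acid, since only methyl and tert-butyl can be compared here. Also open, going by these compounds, is whether tert-butyl in place of bromo on the longer chain of compound 1 would lower the number in the same way.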